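From compound 2 to compound 3: an aryl swap

This account rests on a few compounds, and the source may have more. Where it says the series, first, only, none or still open, it means among the compounds named here.

In a functional assay on BT-483 cells (Homo sapiens) for cytotoxicity, read by MTT assay, with a stated time of 24 h (on this read-out higher numbers stand for weaker inhibition and lower numbers for stronger inhibition), compound 1 (`CCNc1cc(-c2ccc(NC(=O)Nc3c(C)cccc3C)cc2C(F)(F)F)ccn1`) gives 22000 nM as its reading. Compound 2 (`CCNc1cc(-c2ccc(NC(=O)Nc3ccc(C(F)(F)F)cc3)cc2OC)ccn1`) gives 25600 nM as its reading, which lies within the scatter of the compound 1 value. Compound 3 (`CCNc1cc(-c2ccc(NC(=O)Nc3c(C)cccc3C)cc2OC)ccn1`) differs from compound 2 in one place, with 2,6-dimethylphenyl in place of 4-(trifluoromethyl)phenyl on an amide-type nitrogen. Among the compounds with values here, no measured step for this swap exists. Within the data shown here, the only guide is that compound 1, which also carries 2,6-dimethylphenyl on an amide-type nitrogen, reads 22000 nM in this assay and thus sits within the scatter of compound 2. An estimated step of a 1.1-fold lower number from compound 2 to compound 3 (0.05 log units; within the scatter) is therefore expected to stay within the scatter, with no firm direction. For compound 3 the estimated value is 23000 nM with an expected range from 12000 nM to 45000 nM in this read-out.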

Compound 3, half-maximal inhibitory concentration: > 30000 nM
Compound 3 gave a limit, no number; the forecaster's own chance of this, stated with the estimate: 8%; at least 1.3-fold (0.11 log units) between middle value and limit.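

In this assay compound 3 gives > 30000 nM, which is a limit of the assay and not a number: the limit of > 30000 nM in this assay, at which 1 of the 3 values shown sits.

Two single-place comparisons now exist in the series: 2,6-dimethylphenyl in place of 4-(trifluoromethyl)phenyl on an amide-type nitrogen gives an at least 1.1-fold higher number from compound 2 to compound 3 (0.06 log units; that floor lies within the scatter) and methoxy in place of trifluoromethyl on an aromatic carbon gives an at least 1.3-fold higher number from compound 1 to compound 3 (0.13 log units; that floor lies within the scatter) as the second comparison. Both steps are floors within the scatter, so neither change is shown to move the reading beyond it, and neither brings a lower number.

As far as these compounds go, how far compound 3 lies past its limit remains unknown, so the full size of both steps cannot be read. From the compounds shown here alone, whether an amine or a carboxylic acid in place of methoxy on that aromatic carbon would give a clearly lower number remains open.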